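The compounds below may be only part of what the source reports. "The series", "measured", "known", "first", "only" and "open" are said of these compounds alone.

In a functional assay on aorta for antagonist activity at Alpha-1D adrenergic receptor (Rattus norvegicus) (on this read-out higher numbers stand for weaker binding and lower numbers for tighter binding), compound 2 `CN(C)C(=O)c1cccnc1NCCCN1CCN(c2ccccc2OCC2CC2)CC1` gives 10 nM, the lowest of the two numbers recorded, while compound 1 `CN(C)C(=O)c1cccnc1NCCCN1CCN(c2ccccc2OCC(F)(F)F)CC1` gives 15.9 nM. Among the compounds with values here, the one measured step, a 1.6-fold lower number from compound 1 to compound 2 (0.20 log units; within the scatter), alters only the end of an ether chain. Compound 3 `CN(C)C(=O)c1cccnc1NCCCN1CCN(c2ccccc2-c2ccccc2)CC1` differs from compound 2 by phenyl in place of cyclopropylmethoxy on an aromatic carbon. Within the data shown here, that change removes the ether oxygen and brings in an aromatic ring, which no measured step addresses, so neither its size nor its direction can be read from the data. Compound 3 is estimated at 25 nM, with a range from 8 nM to 80 nM, meaning an expected step of a 2.5-fold higher number from compound 2 to compound 3 (0.40 log units; beyond the scatter).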

Compound 3, dissociation constant: 63.1 nM
Beside the measured number, compound 3's estimate is 2.5-fold (0.40 log units) below it, and the stated range covers the measured number.
By their numbers in this assay, from the lowest: compounds 2 and 1 (each within the scatter of the next); then compound 3.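

Unlike the earlier change at the end of the ether chain, which stayed within the scatter, replacing the whole ether on this aromatic carbon with phenyl moves the number beyond the scatter in this assay, with a 6.3-fold higher number from compound 2 to compound 3 (0.80 log units; beyond the scatter) and a 4.0-fold higher number from compound 1 to compound 3 (0.60 log units; beyond the scatter) for the same swap. In these three compounds, both ether-linked groups therefore give lower numbers than phenyl. On these data alone, whether a simple methoxy group or an amine on this carbon would keep the lower numbers remains open. Nothing at hand explains why phenyl gives the higher number.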